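Rearranging the hydroxyalkyl chain on a shared core

The compounds below may be only part of what the source reports. "The series", "measured", "known", "first", "only" and "open" are said of these compounds alone.

Compound 2 `COc1cc(Cc2nc3c(N)ncnc3n2CC(C)CCCO)cc(OC)c1OC` gives the lowest number of the two measured compounds in a functional assay on MCF7 cells (Homo sapiens) for cytotoxicity (a higher number here means that more compound is needed for the effect, a lower number that less compound is needed), at 8770000 nM; compound 1 `COc1cc(Cc2nc3c(N)ncnc3n2CCCO)cc(OC)c1OC` gives 92700000 nM. Within the data shown here, the one measured step, an 11-fold lower number from compound 1 to compound 2 (1.02 log units; beyond the scatter), involved lengthening the chain on the ring nitrogen. Compound 3 `CCC(CO)CCn1c(Cc2cc(OC)c(OC)c(OC)c2)nc2c(N)ncnc21` carries the change (2-(hydroxymethyl)butyl in place of 4-hydroxy-1-methylbutyl on a saturated chain carbon bound to an aromatic nitrogen), a reshuffling of the same atoms rather than a change in their count. Among the measured compounds shown here, no measured step tests such a rearrangement, so no shift beyond the scatter is expected in this assay; compound 3 is estimated at 12000000 nM, within 3000000 nM to 50000000 nM, a step of a 1.4-fold higher number from compound 2 to compound 3 (0.14 log units; within the scatter).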

Compound 3, half-maximal effective concentration: 19200000 nM
Compound 3: the middle estimate sits 1.6-fold (0.20 log units) below what was measured, within the range that was stated.
By their numbers in this assay, from the lowest: compound 2; then compound 3; then compound 1.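

Arrangement matters at this position, not just the atoms present: in this assay, 2-(hydroxymethyl)butyl in place of 4-hydroxy-1-methylbutyl on a saturated chain carbon bound to an aromatic nitrogen gives a 2.2-fold higher number from compound 2 to compound 3 (0.34 log units; beyond the scatter). The rearranged chain still keeps part of the gain over the shorter chain, with a 4.8-fold lower number from compound 1 to compound 3 (0.68 log units; beyond the scatter). Nothing available accounts for either shift. From the compounds shown here alone, whether a longer chain would lower the number further remains open, as does the effect of an amine or a carboxylic acid in place of the hydroxyl.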